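Formyl series: chloro to methyl on the aryl

The source may report more compounds than this note shows. Statements on the series, on what has been measured and on what is new or still open speak of the compounds shown alone.

Compound 3 `O=CN1N=C(c2ccc(Cl)cc2)CC1c1cn(-c2ccccc2)nc1-c1ccc(Cl)c(Cl)c1` carries a formyl group on the ring nitrogen and gives 57.8% in a functional assay on the whole organism (strain Wistar) for inhibition, with Rattus norvegicus as the target, read by paw edema, with stated times of 30 min and 120 min, at a dose of 50 mg/kg by the oral route; a lower number here means less inhibition, a higher number more inhibition at the dose given (going by the name of the read-out). Of the three measured compounds it stands lowest. Compound 1 `Cc1ccc(C2=NN(c3ccc([N+](=O)[O-])cc3)C(c3cn(-c4ccccc4)nc3-c3ccc(Cl)c(Cl)c3)C2)cc1` gives 71.9% and compound 2 `CCC(=O)N1N=C(c2ccc(C)cc2)CC1c1cn(-c2ccccc2)nc1-c1ccc(Cl)c(Cl)c1` gives 70.3%; both of these carry 4-methylphenyl rather than 4-chlorophenyl, and both sit beyond the scatter above compound 3.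

Compound 4 `Cc1ccc(C2=NN(C=O)C(c3cn(-c4ccccc4)nc3-c3ccc(Cl)c(Cl)c3)C2)cc1` is not yet measured. It differs from compound 3 in one place: methyl in place of chloro on an aromatic carbon. The methyl enters on an aromatic carbon of a six-membered aromatic ring of carbon only, para to a large group, so compound 4 keeps the formyl of compound 3 and takes the 4-methylphenyl of compounds 1 and 2.

Within the data shown here, the only measured step, a number 1.6 percentage points lower from compound 1 to compound 2 (within the scatter), concerns the group on the ring nitrogen, not the aryl, and does not bear on this change. Among the measured compounds shown here, no measured pair isolates methyl against chloro; compounds 2 and 3 differ at two places at once, so their gap cannot be assigned. The expectation therefore rests on compound 4 sharing its aryl with compound 2, which gives 70.3%, and its ring-nitrogen group with compound 3. An upward step a number 6.2 percentage points higher from compound 3 to compound 4 (within the scatter) is expected, of a size that may or may not clear the scatter. Compound 4 is estimated at 64%, within 52% to 76%.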

Compound 4, a percentage reported as inhibition, in the whole organism at one dose (the size of the read-out at that dose, not a potency): 60.9%
Beside the measured number, compound 4's estimate is 3.1 percentage points above it; low and high end bracket the measured number.
By their numbers in this assay, from the lowest: compounds 3, 4, 2 and 1 (each within the scatter of the next, the first and the last beyond it).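

In this assay the change from 4-chlorophenyl to 4-methylphenyl can now be read alone with the formyl held fixed, and methyl in place of chloro on this aromatic carbon, para to a large group, gives a number 3.1 percentage points higher from compound 3 to compound 4 (within the scatter) as its step. With the 4-methylphenyl held fixed, the group on the ring nitrogen can also be read against the formyl: hydrogen in place of ethyl on the carbonyl carbon gives a number 9.4 percentage points lower from compound 2 to compound 4 (within the scatter) as its step, while formyl in place of 4-nitrophenyl gives a number 11 percentage points lower from compound 1 to compound 4 (beyond the scatter) as its step, and only this last one clears the scatter. No data in hand bear on the cause of any of these steps.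

The compounds shown leave open how a methoxy or a hydroxyl group would read at this place on the aromatic ring, and whether the reading for methyl against chloro carries over to compounds with propanoyl or 4-nitrophenyl on the ring nitrogen. They also leave open how a longer acyl chain or an acyl group bearing an amine would read on that nitrogen.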